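The source may report more compounds than this note shows. Statements on the series, on what has been measured and on what is new or still open speak of the compounds shown alone.

Measured in a functional assay on A549 cells (Homo sapiens) for antiproliferative activity, with a stated time of 72 h; on this read-out lower numbers stand for stronger inhibition and higher numbers for weaker inhibition:
- compound 1 `COc1cc(OC)c(C(=O)/C=C/c2ccccc2Cl)c(O)c1CN(C)CC(=O)O`: 79400 nM
- compound 2 `CCN(C)Cc1c(OC)cc(OC)c(C(=O)/C=C/c2ccccc2Cl)c1O`: 1300 nM
- compound 3 `CCN(CC)Cc1c(OC)cc(OC)c(C(=O)/C=C/c2ccccc2Cl)c1O`: 3600 nM

Compound 3 holds the second highest of the three numbers. It lies nearer to compound 2 than to compound 1, as shown by a 2.8-fold higher number from compound 2 to compound 3 (0.44 log units; beyond the scatter) and a 22-fold lower number from compound 1 to compound 3 (1.34 log units; beyond the scatter).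

The next compound is compound 4 `COc1cc(OC)c(C(=O)/C=C/c2ccccc2Cl)c(O)c1CN(C)CCCN(C)C`. It carries (3-(dimethylamino)propyl)(methyl)amino in place of diethylamino on a saturated chain carbon bound to an aromatic carbon.

Among the measured compounds shown here, no measured compound carries the entering group, so the measured steps give only loose guidance. The closest is a 2.8-fold higher number from compound 2 to compound 3 (0.44 log units; beyond the scatter), a modest step for a small change on the same amine nitrogen. For the measured compounds named here, the large steps, a 61-fold lower number from compound 1 to compound 2 (1.79 log units; beyond the scatter) and a 22-fold lower number from compound 1 to compound 3 (1.34 log units; beyond the scatter), both start from compound 1, the only measured compound with a carboxy group. Compound 4 has no carboxy group, so a change of that size is not expected in this assay. No clear direction follows from these three compounds, and a step within the scatter is the most likely outcome, though with wide uncertainty.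

The expected step is a 1.2-fold lower number from compound 3 to compound 4 (0.08 log units; within the scatter).

For compound 4 the estimated value is 3000 nM, with an expected range from 800 nM to 11000 nM.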

Compound 4, half-maximal inhibitory concentration: 3100 nM
The estimate for compound 4 lay 1.0-fold (0.01 log units) below the measured number, and the stated range covers the measured number.
By their numbers in this assay, from the lowest: compound 2; then compounds 4 and 3 (each within the scatter of the next); then compound 1.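

In this assay, a much larger side chain is accepted on a saturated chain carbon bound to an aromatic carbon: (3-(dimethylamino)propyl)(methyl)amino, with 8 heavy atoms and 2 nitrogens, replaces diethylamino, with 5 heavy atoms and 1 nitrogen, and gives a 1.2-fold lower number from compound 3 to compound 4 (0.06 log units; within the scatter). Compound 4 also stays modestly apart from the smaller amine of compound 2, with a 2.4-fold higher number from compound 2 to compound 4 (0.38 log units; beyond the scatter), a gap much like a 2.8-fold higher number from compound 2 to compound 3 (0.44 log units; beyond the scatter). The large distance from the carboxy-bearing compound 1 now holds for a third partner without a carboxy group, with a 26-fold lower number from compound 1 to compound 4 (1.41 log units; beyond the scatter), and none of the three amines shown goes against it.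

No measurement shown gives a reason for any of these steps. Still open, going by these compounds, is how a cyclic amine such as piperidine or morpholine, or a longer chain joining the two amine nitrogens, would read on a saturated chain carbon bound to an aromatic carbon in this assay.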